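The compounds below may be only part of what the source reports. "The series", "measured", "known", "first", "only" and "open" are said of these compounds alone.

Measured compounds:
- compound 1, `CCOC(=O)C1=Cc2ccccc2OC1(OCc1cn(-c2ccc(F)cc2)nn1)C(F)(F)F`, 8400 nM
- compound 2, `CCOC(=O)C1=Cc2ccccc2OC1(OCc1cc(-c2ccc(Br)cc2)no1)C(F)(F)F`, 52300 nM
- compound 3, `O=C(O)C1=Cc2ccccc2OC1(OCc1cc(-c2ccc([N+](=O)[O-])cc2)no1)C(F)(F)F`, > 150000 nM

Series notes. All three share one core and differ in the pendant aryl-substituted five-membered ring and in the ester versus acid. In a functional assay on HeLa cells (Homo sapiens) for inhibition, read by MTT assay, with a stated time of 24 h (a higher number here means a weaker inhibitor, a lower number a stronger inhibitor), compound 1 gives 8400 nM and stands lowest of the two numbers shown; compound 2 gives 52300 nM, a higher number that lies beyond the scatter. For compound 3 only a limit is available in this assay, (the limit of > 150000 nM in this assay, at which 1 of the 3 values shown sits), so no number can be placed for it.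

The next compound, compound 4, `CCOC(=O)C1=Cc2ccccc2OC1(OCc1cn(-c2cccc(C(F)(F)F)c2)nn1)C(F)(F)F`, is not yet measured in this assay. It differs from compound 1 in one place: 3-(trifluoromethyl)phenyl in place of 4-fluorophenyl on an aromatic nitrogen. Among the compounds with values here, no step between two measured compounds of this kind is at hand, so the expectation rests on compound 1 alone. The change keeps the ester and the five-membered ring with three nitrogens of compound 1 and swaps only the aryl group on the aromatic nitrogen, so the step is expected to be small and, if anything, toward a slightly higher number, a 1.3-fold higher number from compound 1 to compound 4 (0.12 log units; within the scatter), estimated. For compound 4 in this assay the estimate is 11000 nM, expected to fall between 3500 nM and 35000 nM.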

Compound 4, half-maximal inhibitory concentration: > 150000 nM
Compound 4: no number, only a limit; the forecaster's own chance of this, stated with the estimate: 5%; middle value at least 13-fold (1.13 log units) from the limit.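

In this assay the aryl group on the aromatic nitrogen of the five-membered ring with three nitrogens proves to be a sensitive position: 3-(trifluoromethyl)phenyl in place of 4-fluorophenyl gives an at least 17-fold higher number from compound 1 to compound 4 (1.25 log units; beyond the scatter) and leaves the ester and the rest of the shared core unchanged. Within the data shown here, the earlier compounds offered no step between measured compounds that differ in one place, so this is the first reading of this aryl group on its own, and the change is far from neutral. Compound 4 has a limit and not a number, so the step marks only a minimum and its full size remains unknown: the limit of > 150000 nM in this assay, at which 2 of the 4 values shown sit.

The compounds shown leave open whether the step follows from the trifluoromethyl group itself or from the substituent's place on the phenyl ring, as both differ between the two aryl groups. A 4-(trifluoromethyl)phenyl or a 3-fluorophenyl group on the same nitrogen would separate these two readings, and a carboxylic acid in place of the ethyl ester on the core of compound 1 would test whether this aryl group's effect depends on the ester.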